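Removing One Methoxy Group: Expected Effect on Cell Growth

A few compounds are considered here, and "the series" means these few. Any claim that something is new, unique, unknown or untested is made for them only; others in the source may bear on it.

Compound 1 `COc1cc(-c2cc(/C=C/C(=O)c3ccc(N)cc3)[nH]n2)cc(OC)c1OC` gives 92% in a functional assay on SR cells (Homo sapiens) for cytotoxicity, read by sulforhodamine B assay, with a stated time of 48 h, tested at 0.01 uM; on this read-out lower numbers stand for a stronger effect and higher numbers for a weaker effect at the one concentration tested.
Compound 2 `COc1ccc(-c2cc(/C=C/C(=O)c3ccc(N)cc3)[nH]n2)cc1OC` gives 98% in this assay.
Compound 3 `COc1cc(C(=O)/C=C/c2cc(-c3cc(OC)c(OC)c(OC)c3)n[nH]2)cc(OC)c1OC` gives 111% in this assay.

Compound 4 `COc1ccc(-c2cc(/C=C/C(=O)c3cc(OC)c(OC)c(OC)c3)[nH]n2)cc1OC` has not yet been measured in this assay. It is derived from compound 3 by a single change: hydrogen in place of methoxy on an aromatic carbon. The same change has already been measured once, from compound 1 to compound 2: hydrogen in place of methoxy on an aromatic carbon. That step gave a number 6 percentage points higher from compound 1 to compound 2 (within the scatter), so removing the methoxy group left the read-out essentially unchanged in that pair. Compound 3 and compound 1 differ in more than one place, and the difference between the two cores is not broken down here. Among the three measured numbers, compound 3 stands highest, beyond the scatter from both compound 2 and compound 1, meaning it has the weakest effect on cell growth at the single concentration tested.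

Since the change in the measured pair gave only a number 6 percentage points higher from compound 1 to compound 2 (within the scatter), the expected step is a number 2 percentage points higher from compound 3 to compound 4 (within the scatter), a small movement upward at most. Compound 4 is therefore estimated at 113%, with a likely range from 96% to 130%. Going by the values given here, only one measured pair shows this change, so the range is kept wide.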

Compound 4, a percentage reported as activity, at one concentration (the size of the read-out at that concentration, not a potency): 93%
The estimate for compound 4 lay 20 percentage points above the measured number, outside the stated range (below it).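

In this assay, hydrogen in place of methoxy gave a number 18 percentage points lower from compound 3 to compound 4 (beyond the scatter), which on this read-out means a stronger effect on the cells, whereas the same change left the earlier pair essentially unchanged. The result of this change therefore did not carry over from one core to the other: the same change on two cores in this assay, a number 6 percentage points higher (within the scatter) from compound 1 to compound 2 and a number 18 percentage points lower (beyond the scatter) from compound 3 to compound 4, 24 percentage points apart, beyond the scatter of two such steps

This shows that, in these two pairs, the outcome of removing a methoxy group depends on the core it sits on, so a step measured on one core is a poor guide to the other; it does not show which difference between the cores is responsible, and two pairs cannot predict what the change would do on a further core.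

The compounds shown leave open what other groups at this place on the aromatic ring would do, such as a hydroxyl group, a chlorine atom or a longer ethoxy chain. They also leave open whether the step seen here would hold at other concentrations or in other cell lines.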